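The source may hold more compounds than are shown below. What is called first, only, known or untested is meant among the compounds shown, and "the series" means these compounds.

Of the compounds shown here, two have so far been measured in an assay on isolated protein for inhibition of malate dehydrogenase, mitochondrial (Sus scrofa), with stated times of 45 min and 30 min; on this read-out lower numbers stand for stronger inhibition and higher numbers for weaker inhibition. Compound 1 `O=S(=O)(Nc1ccc(-c2nc3ccccc3o2)cc1)c1cccc(F)c1` returns only a limit of the assay rather than a number, > 63000 nM. Compound 2 `Cc1ccc(S(=O)(=O)Nc2ccc3oc(-c4ccccc4)nc3c2)cc1` also returns a limit rather than a number, > 63000 nM. Both shown values therefore sit at the same point, (the limit of > 63000 nM in this assay, at which 2 of the 2 values shown sit), so compound 2 stands at the edge of what this assay reports, with no ranking possible against compound 1. Within the data shown here, no step between measured compounds is available. Compound 3 `C=Cc1ccc(S(=O)(=O)Nc2ccc3oc(-c4ccccc4)nc3c2)cc1` differs from compound 2 in one place: vinyl in place of methyl on an aromatic carbon, para to a large group. With compound 2 at a limit, no direction can be read from the shown numbers. The expected step in this assay is none beyond the scatter, a number no higher from compound 2 to compound 3 (the limit leaves the size open). Compound 3 is thus estimated at 63000 nM, within 25000 nM to 160000 nM, most probably reported again as a limit.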

Compound 3, half-maximal inhibitory concentration: > 63000 nM
Compound 3 was reported as a limit; the forecaster's own chance of this, stated with the estimate: 85%; the middle value lies on the limit itself.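

Compound 2 and compound 3 are both reported only as limits in this assay, so no step can be read between them: the limit of > 63000 nM in this assay, at which 3 of the 3 values shown sit.

The compounds shown leave open whether vinyl in place of methyl on an aromatic carbon changes inhibition at all, and whether any compound of the series gives a measurable number.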